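Para-halogen swap on the aryl ring of the shared core

This account rests on a few compounds, and the source may have more. Where it says the series, first, only, none or still open, it means among the compounds named here.

Notes on the series. Compound 1 `CCOC(=O)c1c(C)[nH]c(=O)c(C#N)c1-c1ccc(OC)cc1` and compound 2 `CCOC(=O)c1c(C)[nH]c(=O)c(C#N)c1-c1ccc(F)cc1` share a core and differ only at the aromatic carbon of the pendant ring. In a functional assay on SK-OV-3 cells (Homo sapiens) for inhibition, read by MTT assay, with a stated time of 24 h (a higher number here means a weaker inhibitor, a lower number a stronger inhibitor), compound 1 gives only a limit, > 100000 nM. In this assay compound 2 likewise gives only a limit, > 100000 nM. Compound 2 therefore stands at the edge of what this assay resolves, with no number of its own. The step from compound 1 to compound 2, a step that the two limits leave unreadable from compound 1 to compound 2, cannot be read in size because of the limit of > 100000 nM in this assay, at which 2 of the 2 values shown sit.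

Compound 3 `CCOC(=O)c1c(C)[nH]c(=O)c(C#N)c1-c1ccc(Br)cc1` is the next member. The change from compound 2 to compound 3 is bromo in place of fluoro on an aromatic carbon. For the measured compounds named here, the one measured step that bears on a para-halogen exchange on this ring is the unreadable one above, so it sets no expectation of a step beyond the scatter in either direction in this assay. For compound 3 the expected value is 100000 nM, with a range from 30000 nM to 300000 nM. The step from compound 2 to compound 3 is thus estimated at a number no higher from compound 2 to compound 3 (the limit leaves the size open), and a further limit rather than a number is considered the more likely outcome.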

Compound 3, half-maximal inhibitory concentration: > 100000 nM
Compound 3 ended at the assay's limit; the forecaster's own chance of this, stated with the estimate: 70%; the middle value sits exactly at the limit.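

For the compounds shown here, compound 3, like compound 1 and compound 2, gives only a limit in this assay, and no step among the three can be read: the limit of > 100000 nM in this assay, at which 3 of the 3 values shown sit.

The compounds shown leave open whether methoxy, fluoro or bromo on this aromatic carbon makes any difference to inhibition in this assay.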